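Aryl group exchange on the chain: working notes

The source may report more compounds than this note shows. Statements on the series, on what has been measured and on what is new or still open speak of the compounds shown alone.

Measured so far in a functional assay on MCF7 cells (Homo sapiens) for cytotoxicity, read by MTT assay, with a stated time of 72 h (a lower number here means a stronger inhibitor, a higher number a weaker inhibitor), for two compounds
- compound 1 `COc1ccc(/C=C/C(=O)Nc2cc3c(Nc4ccc(F)c(Cl)c4)ncnc3cc2O[C@H]2CCOC2)c(OC)c1` gives 28600 nM
- compound 2 `COc1cc(/C=C/C(=O)Nc2cc3c(Nc4ccc(F)c(Cl)c4)ncnc3cc2O[C@H]2CCOC2)cc(OC)c1O` gives 30500 nM

Compound 2 stands within the scatter of compound 1, so the two are not ranked. Next to be measured is compound 3 `O=C(/C=C/c1ccc(F)cc1Cl)Nc1cc2c(Nc3ccc(F)c(Cl)c3)ncnc2cc1O[C@H]1CCOC1`. The change 2-chloro-4-fluorophenyl in place of 4-hydroxy-3,5-dimethoxyphenyl on a double-bonded chain carbon bound to a double-bonded chain carbon puts 2-chloro-4-fluorophenyl in place of 4-hydroxy-3,5-dimethoxyphenyl on a double-bonded chain carbon bound to a double-bonded chain carbon. For the measured compounds named here, the one measured step at this place is a 1.1-fold higher number from compound 1 to compound 2 (0.03 log units; within the scatter) and it stayed within the scatter. Going by the values given here, no measured compound carries a halogen in this group, so the support is thin. On that single step, no change beyond the scatter is expected in this assay here. The expected size is a 1.3-fold lower number from compound 2 to compound 3 (0.10 log units; within the scatter) as estimated. For compound 3 the estimated value is 24000 nM with an expected range from 8000 nM to 50000 nM for now.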

Compound 3, half-maximal inhibitory concentration: 26200 nM
Beside the measured number, compound 3's estimate is 1.1-fold (0.04 log units) below it; measured number inside the range.
By their numbers in this assay, from the lowest: compounds 3, 1 and 2 (each within the scatter of the next).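

In this assay, for the compounds shown here, the first halogen-bearing group at this place, 2-chloro-4-fluorophenyl, gives no change beyond the scatter against either oxygen-bearing aryl group (a 1.2-fold lower number from compound 2 to compound 3 (0.07 log units; within the scatter); a 1.1-fold lower number from compound 1 to compound 3 (0.04 log units; within the scatter)). The entering group has 0 hydrogen-bond donors and 0 hydrogen-bond acceptors, yet the number holds within the scatter, so this exchange does not separate the compounds in this assay. Nothing measured here accounts for this result.

From the compounds shown here alone, it remains open whether any group at this place can move the number beyond the scatter. An amine, a carboxylic acid on the aryl ring or a longer chain in place of the aryl group would bear on that.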